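Fluoro for methoxy: from compound 2 to compound 3

The compounds below may be only part of what the source reports. "The series", "measured", "known", "first", "only" and "open" are said of these compounds alone.

Measured so far in a physicochemical assay, with a stated time of 30 min; a higher number here means a weaker inhibitor, a lower number a stronger inhibitor
compound 1 `COc1cccc(NC(=O)C2Cc3cc(OC)c(OC)cc3C2=O)c1` gives 38.9 ug/mL in this series
compound 2 `COc1ccccc1NC(=O)C1Cc2cc(OC)c(OC)cc2C1=O` gives 45.8 ug/mL in this series

Within the data shown here, only one other value stands beside compound 2, and the two lie within the scatter of each other. Next comes compound 3 `COc1cc2c(cc1OC)C(=O)C(C(=O)Nc1ccccc1F)C2`, with fluoro in place of methoxy on an aromatic carbon, ortho to a large group (fluoro in place of methoxy on an aromatic carbon). Among the measured compounds shown here, the one measured step has 2-methoxyphenyl in place of 3-methoxyphenyl (a 1.2-fold higher number from compound 1 to compound 2 (0.07 log units; within the scatter)) and bears on this change only indirectly. For the measured compounds named here, no fluoro compound has been measured yet. Resting on compound 2 (45.8 ug/mL) and that small step, no step beyond the scatter is expected in this assay, and no direction is favoured. The expected change is small (a 1.1-fold lower number from compound 2 to compound 3 (0.06 log units; within the scatter)). The estimate for compound 3 is 40 ug/mL (expected range 18 ug/mL to 85 ug/mL).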

Compound 3, half-maximal inhibitory concentration: 75.7 ug/mL
Compound 3: middle estimate off by 1.9-fold (0.28 log units), on the low side; low and high end bracket the measured number.
By their numbers in this assay, from the lowest: compounds 1, 2 and 3 (each within the scatter of the next).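

In this assay, 2-fluorophenyl in place of 2-methoxyphenyl gives a 1.7-fold higher number from compound 2 to compound 3 (0.22 log units; within the scatter) and so shows that, on this aromatic carbon, ortho to a large group, fluoro can replace methoxy without a step beyond the scatter. Read against the 3-methoxyphenyl group, the same 2-fluorophenyl group gives a 1.9-fold higher number from compound 1 to compound 3 (0.29 log units; within the scatter) and so also stays within the scatter, which means that all three groups on the amide nitrogen remain unseparated in this assay. Nothing available explains either step.

Still open, on these data alone, is whether a group of another kind on this aromatic carbon, such as an amine or a carboxylic acid, would produce a step beyond the scatter. Also open, as far as these compounds go, is whether changing the two methoxy groups on the shared core would do so.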